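Cyclohexyl to 1,1-dimethylpropyl: cytotoxicity expectation for compound 3

A few compounds are considered here, and "the series" means these few. Any claim that something is new, unique, unknown or untested is made for them only; others in the source may bear on it.

Two compounds from this series have been examined in an ADME assay on Huh-7 cells (Homo sapiens) for cytotoxicity, with a stated time of 72 h (on this read-out lower numbers stand for higher toxicity in this test and higher numbers for lower toxicity in this test), and both returned only limits of the assay rather than numbers. Compound 1, `CCS(=O)(=O)Nc1ccc2c(c1)S(=O)(=O)N=C(c1c(O)c(-c3cccs3)nn(CCC(C)C)c1=O)N2`, gave > 33000 nM, which is a limit of this assay. Compound 2, `CC(C)CCn1nc(C2CCCCC2)c(O)c(C2=NS(=O)(=O)c3cc(NS(C)(=O)=O)ccc3N2)c1=O`, gave > 1000 nM, again a limit rather than a measured concentration. Compound 2 therefore stands at the lower of the two limits shown, (the limit of > 1000 nM in this assay, at which 1 of the 2 values shown sits), while compound 1 sits at the limit of > 33000 nM in this assay, at which 1 of the 2 values shown sits; the two values show no measured difference between them, only that neither reached half-maximal cytotoxicity within the range tested.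

Compound 3, `CCC(C)(C)c1nn(CCC(C)C)c(=O)c(C2=NS(=O)(=O)c3cc(NS(C)(=O)=O)ccc3N2)c1O`, differs from compound 2 by a single change: 1,1-dimethylpropyl in place of cyclohexyl on an aromatic carbon. For the measured compounds named here, no measured step of this kind is available, so the expectation rests on the two limits alone. Since compound 2 and compound 1 both lie beyond their limits, the step is expected to be none beyond the scatter in this assay, with compound 3 again likely to be reported as a limit, a step that the limit leaves unreadable from compound 2 to compound 3. The estimate for compound 3 in this assay is 20000 nM, with a range from 3000 nM to 100000 nM.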

Compound 3, half-maximal cytotoxic concentration: > 1000 nM
Compound 3 ended at the assay's limit (the forecaster's own chance of this, stated with the estimate: 80%); the middle value lies beyond the limit too.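

Compound 2 and compound 3 both ended at a limit of this assay rather than at a number, so no step can be read between them: the limit of > 1000 nM in this assay, at which 2 of the 3 values shown sit.

The compounds shown leave open whether 1,1-dimethylpropyl in place of cyclohexyl on an aromatic carbon alters the half-maximal cytotoxic concentration at all, and at what concentration compound 2 or compound 3 would reach it.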